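Working notes: bromo in place of ethyl

A few compounds are considered here, and "the series" means these few. Any claim that something is new, unique, unknown or untested is made for them only; others in the source may bear on it.

Measured in a functional assay on SK-OV-3 cells (Homo sapiens) for antiproliferative activity, read by sulforhodamine B assay, with a stated time of 48 h; on this read-out higher numbers stand for weaker inhibition and lower numbers for stronger inhibition
Compound 1 `Cc1cccc(NS(=O)(=O)c2ccc(N3CCNC3=O)cc2)c1` gives 200 nM
Compound 2 `CCc1cccc(NS(=O)(=O)c2ccc(N3CCNC3=O)cc2)c1` gives 230 nM

In this assay, for the measured compounds named here, compound 2 at 230 nM stands within the scatter of compound 1, its only measured neighbour. Compound 3 `O=C1NCCN1c1ccc(S(=O)(=O)Nc2cccc(Br)c2)cc1` is still unmeasured and carries bromo in place of ethyl on an aromatic carbon, 3-ethylphenyl to 3-bromophenyl (bromo in place of ethyl on an aromatic carbon). Going by the values given here, one measured step touches this group: a 1.2-fold higher number from compound 1 to compound 2 (0.06 log units; within the scatter) stays within the scatter. Among the compounds with values here, that step is a different change, methyl in place of hydrogen on a saturated chain carbon, and no bromo compound has been measured, so it offers only weak guidance. No shift beyond the scatter is expected, and the estimated step is a 1.2-fold lower number from compound 2 to compound 3 (0.06 log units; within the scatter) with no direction claimed. For compound 3 the expected value is 200 nM with an estimated range of 90 nM to 450 nM for now.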

Compound 3, half-maximal inhibitory concentration: 170 nM
For compound 3 the middle estimate is 1.2-fold (0.07 log units) above the measured one, within the range that was stated.
By their numbers in this assay, from the lowest: compounds 3, 1 and 2 (each within the scatter of the next).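

In this assay, bromo in place of ethyl on an aromatic carbon gives a 1.4-fold lower number from compound 2 to compound 3 (0.13 log units; within the scatter), and bromo in place of methyl on the same carbon gives a 1.2-fold lower number from compound 1 to compound 3 (0.07 log units; within the scatter). For the compounds shown here, this position, until now seen only with methyl and ethyl, thus also takes a bromo without a step beyond the scatter, even though bromo brings a different element and, compared with ethyl, one heavy atom instead of two. No supporting data explain how closely these three compounds agree.

The compounds shown leave open whether an amine, a carboxylic acid or a longer chain at this position would move the number beyond the scatter. They also leave open whether bromo on another carbon of this ring would behave the same way.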